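The compounds below may be only part of what the source reports. "The series", "measured", "known", "first", "only" and "open" are said of these compounds alone.

Compound 2 `O=C(COc1ccc2cc(/C=C3/SC(=O)NC3=O)ccc2c1)Nc1ccc(Cl)c(Cl)c1` carries a 3,4-dichlorophenyl group on its amide nitrogen. In an assay on isolated protein for inhibition of histone deacetylase 8 (Homo sapiens), with a stated time of 1 h (on this read-out higher numbers stand for weaker inhibition and lower numbers for stronger inhibition), compound 2 reaches only > 50000 nM, which is a limit of the assay rather than a number. Compound 1 `Cc1cc(Br)ccc1NC(=O)COc1ccc2cc(/C=C3/SC(=O)NC3=O)ccc2c1`, which differs from it only by having 4-bromo-2-methylphenyl on that nitrogen, gives 7400 nM in this assay. From the compounds shown here alone, the step of an at least 6.7-fold higher number from compound 1 to compound 2 (0.82 log units; beyond the scatter) shows that swapping that ring weakened the inhibition, though its full size stays open because of the limit of > 50000 nM in this assay, at which 1 of the 2 values shown sits. Compound 3 `Cc1ccc(NC(=O)COc2ccc3cc(/C=C4/SC(=O)NC4=O)ccc3c2)cc1Cl` differs from compound 2 in one place: methyl in place of chloro on an aromatic carbon. Among the compounds with values here, no measured step covers this exact change; the only step known, from compound 1 to compound 2, concerns a different swap on the same ring and leaves compound 2 at the weak end. For compound 3 the step of an at least 1.4-fold lower number from compound 2 to compound 3 (0.15 log units; that floor lies within the scatter) in this assay is expected to be small. Compound 3 is estimated at 35000 nM, within 8000 nM to 150000 nM.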

Compound 3, half-maximal inhibitory concentration: > 50000 nM
Compound 3: only a limit was reported (the forecaster's own chance of this, stated with the estimate: 50%); at least 1.4-fold (0.15 log units) between middle value and limit.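

With methyl in place of chloro at this position on the ring, inhibition still does not reach a measurable value in this assay. The change from the ring of compound 1 to the 3-chloro-4-methylphenyl ring gives an at least 6.7-fold higher number from compound 1 to compound 3 (0.82 log units; beyond the scatter), so a second ring, not only the 3,4-dichlorophenyl one, gives weaker inhibition than compound 1. Any difference between methyl and chloro here cannot be read, because compound 2 and compound 3 both stop at a limit and not at a number: the limit of > 50000 nM in this assay, at which 2 of the 3 values shown sit.

From the compounds shown here alone, it remains open whether another group at this position, such as methoxy, an amine or a carboxylic acid, would give a readable value. Also open, going by these compounds, is whether the bromo or the methyl group on the ring of compound 1 matters more for its measurable inhibition.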